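Phenyl to 4-(trifluoromethyl)benzyl on a weakly inhibiting compound

A few compounds are considered here, and "the series" means these few. Any claim that something is new, unique, unknown or untested is made for them only; others in the source may bear on it.

In a functional assay on MCF7 cells (Homo sapiens) for inhibition, read by CCK-8 assay, with a stated time of 48 h (on this read-out lower numbers stand for stronger inhibition of growth and higher numbers for weaker inhibition of growth), compound 1 (`Cc1ccccc1Nc1nc(Nc2ccc(N3CCNCC3)cn2)ncc1Cl`) gives 3410 nM and compound 2 (`Cc1ccccc1Nc1nc(Nc2ccc(N3CCN(C(=O)OC(C)(C)C)CC3)cc2)ncc1Cl`) gives 2250 nM. Compound 3 (`CN1CCN(c2ccc(Nc3ncc(Cl)c(Nc4ccccc4)n3)nc2)CC1`) gives 51800 nM, the highest of the three numbers and beyond the scatter from both others. Compound 4 (`CN1CCN(c2ccc(Nc3ncc(Cl)c(NCc4ccc(C(F)(F)F)cc4)n3)nc2)CC1`) has 4-(trifluoromethyl)benzyl in place of phenyl on a nitrogen on an aromatic ring. Among the measured compounds shown here, no measured pair shows this change directly, so the expectation is tentative. Compound 3 at 51800 nM leaves far more room for a fall than for a rise, so a lower number is expected in this assay. The expected change is a 5.8-fold lower number from compound 3 to compound 4 (0.76 log units; beyond the scatter), a step beyond the scatter. Compound 4 is estimated at 9000 nM, with an expected range from 2500 nM to 35000 nM.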

Compound 4, concentration for 50% growth inhibition: 28400 nM
The estimate for compound 4 lay 3.2-fold (0.50 log units) below the measured number, and the stated range covers the measured number.
By their numbers in this assay, from the lowest: compounds 2 and 1 (each within the scatter of the next); then compounds 4 and 3 (each within the scatter of the next).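

In this assay, 4-(trifluoromethyl)benzyl in place of phenyl on a nitrogen on an aromatic ring gives a 1.8-fold lower number from compound 3 to compound 4 (0.26 log units; within the scatter) and so leaves the number within the scatter. Among the compounds shown here, this nitrogen therefore carries the larger group, of 11 heavy atoms rather than 6, with no step that can be told from repeat variation. Nothing measured on these compounds offers an explanation for this result.

From the compounds shown here alone, what plain benzyl or phenethyl would give at this nitrogen remains open. So does the effect of a carboxylic acid or an amine on the benzyl ring.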